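Working notes: cyclohexylmethyl in place of hydrogen, compound 2 to 4

The source may report more compounds than this note shows. Statements on the series, on what has been measured and on what is new or still open speak of the compounds shown alone.

Measured so far:
- compound 1, `c1ccc(COC[C@H]2OCC[C@@H](OCc3ccccc3)[C@@H]2OCc2ccccc2)cc1`, 33300 nM
- compound 2, `O[C@H]1CO[C@H](COCc2ccccc2)[C@@H](OCc2ccccc2)[C@@H]1OCc1ccccc1`, > 50000 nM, a limit of the assay
- compound 3, `C=CC[C@@H]1O[C@H](COCc2ccccc2)[C@@H](OCc2ccccc2)[C@H](OCc2ccccc2)[C@H]1OC(C)=O`, > 50000 nM, a limit of the assay

All values come from a functional assay on HeLa cells (Homo sapiens) for antiproliferative activity, read by sulforhodamine B assay; a lower number here means a stronger inhibitor of growth, a higher number a weaker inhibitor of growth. Compound 1 gives the only numerical result of the three. Compound 2 sits at a limit of this assay, so its value is not a number; (the limit of > 50000 nM in this assay, at which 2 of the 3 values shown sit). Among the compounds with values here, the single step measured, an at least 1.5-fold higher number from compound 1 to compound 2 (0.17 log units; that floor lies within the scatter), is itself bounded by that limit and its floor lies within the scatter, so it gives no usable direction. Within the data shown here, compound 3 also returns only a limit, and no step links it to the others.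

The next compound is compound 4, `O[C@@H]1[C@@H](OCc2ccccc2)[C@H](OCc2ccccc2)[C@@H](COCc2ccccc2)O[C@H]1CC1CCCCC1`. It differs from compound 2 as follows: cyclohexylmethyl in place of hydrogen on a saturated ring carbon. Among the measured compounds shown here, no measured step bears on this change, and the one step available is within the scatter, so nothing points to a gain in this assay. With compound 2 and compound 3 both at the limit, compound 4 is expected to stay near it as well, the step from compound 2 being a number no higher from compound 2 to compound 4 (the limit leaves the size open). The estimate for compound 4 is 50000 nM, with a range from 15000 nM to 150000 nM.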

Compound 4, concentration for 50% growth inhibition: 9500 nM
Beside the measured number, compound 4's estimate is 5.3-fold (0.72 log units) above it; measured number outside the range, below it.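

In this assay, cyclohexylmethyl in place of hydrogen on the saturated ring carbon next to the ring oxygen gives an at least 5.2-fold lower number from compound 2 to compound 4 (0.72 log units; beyond the scatter). This is the only step shown that lies beyond the scatter, so this position, next to the ring atom that bears a hydroxy group, is the first place in the series where a single change clearly moves the read-out toward stronger growth inhibition. The figure for the step is a floor and its true size stays open: the limit of > 50000 nM in this assay, at which 2 of the 4 values shown sit.

The compounds shown leave open whether the six-membered carbon ring of cyclohexylmethyl is needed at this position, or whether a propyl chain or an aminomethyl group on the same ring carbon would give a comparable step. They also leave open whether the hydroxy group matters to the step, as no pair shown keeps cyclohexylmethyl in place while replacing that hydroxy group with, for example, a methoxy group or an amine.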